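This account rests on a few compounds, and the source may have more. Where it says the series, first, only, none or still open, it means among the compounds named here.

Values in an ADME assay on BCBL1 cells (Homo sapiens) for cytotoxicity, with a stated time of 7 days; a higher number here means that more compound is tolerated, a lower number that less compound is tolerated:
Compound 1 `CNc1nc(N)nc2c1ncn2/C=C1/CC1(CO)CO`: 67000 nM
Compound 2 `CCOc1nc(N)nc2c1ncn2/C=C1/CC1(CO)CO`: > 20000 nM, a limit
Compound 3 `Nc1nc(NC2CCCC2)c2ncn(/C=C3/CC3(CO)CO)c2n1`: 71700 nM

Compound 3 stands level with the other measured number, a 1.1-fold higher number from compound 1 to compound 3 (0.03 log units; within the scatter). Compound 4 `CSc1nc(N)nc2c1ncn2/C=C1/CC1(CO)CO` carries methylsulfanyl in place of cyclopentylamino on an aromatic carbon. Within the data shown here, that readable step is the only sized guide at this place, and it shows no movement beyond the scatter. Two further steps bear on the change but give no size: a step that the limit leaves unreadable from compound 1 to compound 2 and a step that the limit leaves unreadable from compound 2 to compound 3. No step beyond the scatter is therefore expected, and the estimate is a 1.4-fold lower number from compound 3 to compound 4 (0.16 log units; within the scatter). Compound 4 is estimated at 50000 nM, with an expected range of 18000 nM to 100000 nM.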

Compound 4, half-maximal cytotoxic concentration: > 20000 nM
Compound 4 was reported as a limit (the forecaster's own chance of this, stated with the estimate: 35%); the middle value does not contradict the limit.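

In this assay, among these compounds, compound 4 gives > 20000 nM, a limit, so no step between it and compound 1, compound 2 or compound 3 can be read. The compounds shown leave open whether methylsulfanyl or ethoxy differs at all from methylamino or cyclopentylamino on this aromatic carbon: the limit of > 20000 nM in this assay, at which 2 of the 4 values shown sit.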